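This account rests on a few compounds, and the source may have more. Where it says the series, first, only, none or still open, it means among the compounds named here.

Compound 1 `COc1cc(NC(C)CCCNC(=O)NNC(=O)Nc2ccc(Cl)cc2)c2ncccc2c1`: 120000 nM
Compound 2 `COc1cc(NC(C)CCCNC(=O)NNC(=O)Nc2cccc(Cl)c2)c2ncccc2c1`: 44000 nM
Compound 3 `COc1cc(NC(C)CCCNC(=O)Nc2ccc(O)cc2)c2ncccc2c1`: not yet measured

In a functional assay on HeLa cells (Homo sapiens) for inhibition, read by MTT assay, with a stated time of 72 h (a higher number here means a weaker inhibitor, a lower number a stronger inhibitor), compound 2 gives the lower of the two numbers, 44000 nM. The next structural change is 4-hydroxyphenyl in place of ((3-chlorophenyl)carbamoyl)amino on an amide-type nitrogen. Among the compounds with values here, the only measured step, a 2.7-fold lower number from compound 1 to compound 2 (0.44 log units; beyond the scatter), swaps 4-chlorophenyl for 3-chlorophenyl and bears only loosely on this much larger change. It shows that a change in the aryl group alone can move the number beyond the scatter. A lower number is tentatively expected, with the direction not settled by the data. The estimated change is a 2.2-fold lower number from compound 2 to compound 3 (0.34 log units; beyond the scatter). For compound 3 the estimate is 20000 nM, with an expected range of 5000 nM to 80000 nM.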

Compound 3, half-maximal inhibitory concentration: 70000 nM
For compound 3 the middle estimate is 3.5-fold (0.54 log units) below the measured one, and the stated range covers the measured number.
By their numbers in this assay, from the lowest: compounds 2, 3 and 1 (each within the scatter of the next, the first and the last beyond it).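

In this assay, 4-hydroxyphenyl in place of ((3-chlorophenyl)carbamoyl)amino on this amide-type nitrogen gives a 1.6-fold higher number from compound 2 to compound 3 (0.20 log units; within the scatter), and in place of ((4-chlorophenyl)carbamoyl)amino it gives a 1.7-fold lower number from compound 1 to compound 3 (0.23 log units; within the scatter). Both steps lie within the scatter, so this assay does not separate compound 3 from either chlorophenyl compound, even though the entire carbamoylamino unit has left. No supporting measurement bears on this result.

Still open, on these data alone, is whether an amine or a carboxylic acid in place of the hydroxy group on the phenyl ring would move the number beyond the scatter. The same holds for a longer chain on this nitrogen.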